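Chain Length and Monoamine Oxidase A Inhibition

A few compounds are considered here, and "the series" means these few. Any claim that something is new, unique, unknown or untested is made for them only; others in the source may bear on it.

In an ADME assay on BTI cells for inhibition of Amine oxidase [flavin-containing] A (Homo sapiens), read by fluorescence and Amplex Red, with a stated time of 15 min, tested at 100 uM (on this read-out higher numbers stand for more inhibition at the one concentration tested (going by the name of the read-out) and lower numbers for less inhibition), three compounds have been measured:

compound 1, `C#CCN(C)CCCCCOc1ccc2c(c1)CCC2=O`: 31%
compound 2, `C#CCN(C)CCCCCCOc1ccc2c(c1)CCC2=O`: 4.42%
compound 3, `C#CCN(C)CCCCOc1ccc2c(c1)OCCC2=O`: 22.8%

Compounds 1 and 2 share one core and differ in a single place, ((methyl(propargyl)amino)methyl in place of methyl(propargyl)amino on a saturated chain carbon, five bonds along the chain from an oxygen on an aromatic ring). This change produced the step of a number 26.6 percentage points lower from compound 1 to compound 2 (beyond the scatter). Compound 3 carries a different core; the difference between the two cores is not broken down here. In this assay compound 3 sits nearest to compound 1, the two being within the scatter of each other, while it stands beyond the scatter above compound 2.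

Compound 4, `C#CCN(C)CCCCCOc1ccc2c(c1)OCCC2=O`, has not yet been measured. It is made from compound 3 by (methyl(propargyl)amino)methyl in place of methyl(propargyl)amino on a saturated chain carbon, four bonds along the chain from an oxygen on an aromatic ring. This is the same kind of change as that from compound 1 to compound 2, though the place differs: in the measured pair the carbon lies five bonds along the chain from an oxygen on an aromatic ring, whereas here it lies four bonds along the chain from that oxygen. Among the compounds with values here, because the one measured example of this change gave a number 26.6 percentage points lower from compound 1 to compound 2 (beyond the scatter), a drop is expected for compound 4 as well, though from a lower starting point, so the step is estimated as a number 14.8 percentage points lower from compound 3 to compound 4 (beyond the scatter). On this basis compound 4 is expected to give about 8% in this assay, most plausibly between 0% and 25%.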

Compound 4, a percentage reported as inhibition, at one concentration (the size of the read-out at that concentration, not a potency): 6.04%
For compound 4 the middle estimate is 2 percentage points above the measured one, within the range that was stated.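

In this assay, replacing methyl(propargyl)amino with (methyl(propargyl)amino)methyl on the core of compound 3 gave a number 16.8 percentage points lower from compound 3 to compound 4 (beyond the scatter), so the fall seen on the core of compound 1 appeared again on a second core. The two falls point the same way and cannot be told apart in size: the same change on two cores in this assay, a number 26.6 percentage points lower (beyond the scatter) from compound 1 to compound 2 and a number 16.8 percentage points lower (beyond the scatter) from compound 3 to compound 4, 9.8 percentage points apart, within the scatter of two such steps

Within the data shown here, this supports carrying the change from one of these cores to the other as a loss of inhibition, but it rests on only two pairs, and the change does not sit at the same place in them, lying five bonds along the chain from the oxygen on the aromatic ring in one pair and four bonds along it in the other. Nor does it show that the fall would recur on any further core, or how either pair would behave at another concentration, since each number is a single reading and not a potency.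

The compounds shown leave open whether a shorter chain or a still longer chain would keep to the same direction on either core. They also leave open whether the change would act in the same way with a different amine at the chain end, such as a piperidine or a secondary amine lacking the methyl group.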